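The source may report more compounds than this note shows. Statements on the series, on what has been measured and on what is new or still open speak of the compounds shown alone.

For the measured compounds named here, in a functional assay on the whole organism for inhibition, with Echinochloa esculenta as the target (a higher number here means a weaker inhibitor, a lower number a stronger inhibitor), compound 1 (`S=c1n(-c2ccc(Cl)cc2)c(=S)n2n1CCCC2`) gives 89.1 nM, the lower of the two numbers measured so far. The other measured compound, compound 2 (`S=c1n(-c2ccccc2)c(=S)n2n1CCCC2`), gives 3550 nM. Going by the values given here, the single measured step, with hydrogen in place of chloro on an aromatic carbon, is a 40-fold higher number from compound 1 to compound 2 (1.60 log units; beyond the scatter). Compound 3 (`Cc1cc(Cl)ccc1-n1c(=S)n2n(c1=S)CCCC2`) keeps the chloro group and differs from compound 1 by methyl in place of hydrogen on an aromatic carbon, ortho to a large group and meta to a chloro group. Among the compounds with values here, the measured step shows that one change on this aromatic ring can be large, but it involves a different group at a different place, and no measured step covers a methyl group. A modest rise in this assay is therefore expected, with wide uncertainty. The expected step is a 1.8-fold higher number from compound 1 to compound 3 (0.25 log units; within the scatter). Compound 3 is estimated at 160 nM, within a range of 35 nM to 750 nM.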

Compound 3, half-maximal inhibitory concentration: 2240 nM
Compound 3: middle estimate off by 14-fold (1.15 log units), on the low side; measured number outside the range, above it.
By their numbers in this assay, from the lowest: compound 1; then compounds 3 and 2 (each within the scatter of the next).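

In this assay, for the compounds shown here, the first change at this place on the aromatic ring, methyl in place of hydrogen, ortho to a large group and meta to a chloro group, gives a 25-fold higher number from compound 1 to compound 3 (1.40 log units; beyond the scatter). Going by these compounds alone, the earlier compounds showed only that the chloro group matters, and this step shows that the addition of a single methyl group to compound 1 can also produce a large rise, even with the chloro group kept. No available evidence bears on the reason for this step.

The compounds shown leave open whether a fluoro group, a methoxy group or an amine at this same place would give a comparable rise. They also leave open whether methyl elsewhere on the ring, or methyl on the ring of compound 2, would give a similar step.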